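Replacing the Methylpiperazine with a Piperidinylethylamino Chain

This account rests on a few compounds, and the source may have more. Where it says the series, first, only, none or still open, it means among the compounds named here.

In a functional assay on SK-BR-3 cells (Homo sapiens) for antiproliferative activity, read by MTT assay, with a stated time of 72 h (on this read-out lower numbers stand for stronger inhibition and higher numbers for weaker inhibition), three compounds on one shared core can be compared. Compound 1 `Cc1cc(N(C)C)nc2ccc(NC(=O)c3ccc(Cl)c(Cl)c3)cc12` gives > 50000 nM as a limit and not as a number. Compound 2 `Cc1cc(N2CCCCC2)nc2ccc(NC(=O)c3ccc(Cl)c(Cl)c3)cc12` gives 42500 nM and compound 3 `Cc1cc(N2CCN(C)CC2)nc2ccc(NC(=O)c3ccc(Cl)c(Cl)c3)cc12` gives 6320 nM as the lower of the two true numbers. The gap to its nearest neighbour is a 6.7-fold lower number from compound 2 to compound 3 (0.83 log units; beyond the scatter) and stands as the clearest measured step.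

Compound 4 `Cc1cc(NCCN2CCCCC2)nc2ccc(NC(=O)c3ccc(Cl)c(Cl)c3)cc12` has (2-(piperidin-1-yl)ethyl)amino in place of 4-methylpiperazin-1-yl on the aromatic carbon next to the ring nitrogen, a change counted as (2-(piperidin-1-yl)ethyl)amino in place of 4-methylpiperazin-1-yl on an aromatic carbon and one that keeps the nitrogen count of the group.

The nearest guides are a 6.7-fold lower number from compound 2 to compound 3 (0.83 log units; beyond the scatter) and an at least 7.9-fold lower number from compound 1 to compound 3 (0.89 log units; beyond the scatter) together with an at least 1.1-fold lower number from compound 1 to compound 2 (0.07 log units; that floor lies within the scatter) as the step between the two groups with fewer nitrogens. Among the compounds with values here, none of them involves a chain of this kind, so the expectation is loose: no return towards compound 2 and no step clearly beyond the scatter, if anything towards a lower number. The expected change is a 1.8-fold lower number from compound 3 to compound 4 (0.26 log units; within the scatter) in this estimate. For compound 4 the estimated value is 3500 nM with an expected range from 900 nM to 14000 nM as its ends.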

Compound 4, half-maximal inhibitory concentration: 1800 nM
Beside the measured number, compound 4's estimate is 1.9-fold (0.29 log units) above it, within the range that was stated.
By their numbers in this assay, from the lowest: compound 4; then compound 3; then compound 2. At a limit, above all of these: compound 1.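

Within the data shown here, of the groups at this position, on the aromatic carbon next to the ring nitrogen, (2-(piperidin-1-yl)ethyl)amino gives the lowest number so far, with a 3.5-fold lower number from compound 3 to compound 4 (0.55 log units; beyond the scatter) showing that a second nitrogen need not sit in a ring directly attached to the core. The same piperidine ring, carried on the ethylamino chain and no longer attached directly, gives a 24-fold lower number from compound 2 to compound 4 (1.37 log units; beyond the scatter), the largest step that can be read as an exact size. The step from the dimethylamino compound, an at least 27-fold lower number from compound 1 to compound 4 (1.44 log units; beyond the scatter), is only a floor, as its start is a limit and not a number: the limit of > 50000 nM in this assay, at which 1 of the 4 values shown sits.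

On these data alone, what remains open is whether the step follows the chain, its amino hydrogen or the piperidine at its end. A morpholine or dimethylamino group on the same chain, a propyl chain, or a methyl group on the linking nitrogen would separate these.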